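This account rests on a few compounds, and the source may have more. Where it says the series, first, only, none or still open, it means among the compounds named here.

Working notes on the series, read in a functional assay on MCF7 cells (Homo sapiens) for cytotoxicity, read by MTT assay, with a stated time of 72 h; on this read-out higher numbers stand for weaker inhibition and lower numbers for stronger inhibition.

Compound 1 `Cc1cc(C)n2nc(SCc3cc(=O)c4cc(Cl)ccc4o3)nc2n1` carries a chloro group on its fused ring system. In this assay compound 1 gives > 25000 nM, which is a limit of the assay and not a number.

Compounds 2 and 3 share a second core. Compound 3 `Nc1nnc(SCc2cc(=O)c3cc(Cl)ccc3o2)s1` holds the chloro group; in this assay compound 3 gives > 25000 nM, again a limit. Compound 2 `Nc1nnc(SCc2cc(=O)c3ccccc3o2)s1` is its hydrogen counterpart; in this assay compound 2 gives > 25000 nM, also a limit. The step that the two limits leave unreadable from compound 3 to compound 2 is therefore not readable in size. The change involved is hydrogen in place of chloro on an aromatic carbon.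

How the core of compound 1 differs from the core of compound 3 is not broken down here.

Compound 4 `Cc1cc(C)n2nc(SCc3cc(=O)c4ccccc4o3)nc2n1` is not yet measured. Within the data shown here, it differs from compound 1 by hydrogen in place of chloro on an aromatic carbon, the same change as the one between compound 3 and compound 2, since the two place descriptions agree word for word. Among the measured compounds shown here, the only evidence on this change is the limit of > 25000 nM in this assay, at which 3 of the 3 values shown sit, which gives no direction for it.

On that basis compound 4 is expected to sit at the limit as well: an estimate of 40000 nM, with a range from 15000 nM to 120000 nM. The step this estimate means, a step that the limit leaves unreadable from compound 1 to compound 4, is expected to be flat, resting on the unreadable pair a step that the two limits leave unreadable from compound 3 to compound 2 and on compound 1 at > 25000 nM.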

Compound 4, half-maximal inhibitory concentration: > 25000 nM
Compound 4: a limit, no number; the forecaster's own chance of this, stated with the estimate: 85%; the middle value is on the limit's open side.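

Compound 1 and compound 4 both sit at a limit in this assay, not at a number, so the step between them, hydrogen in place of chloro, cannot be read. The compounds shown leave open whether that change has any effect on either core, and whether the two cores differ at all, as no value falls inside the measurable range: the limit of > 25000 nM in this assay, at which 4 of the 4 values shown sit.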